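Bromo on the shared core of compound 3

The source may report more compounds than this note shows. Statements on the series, on what has been measured and on what is new or still open speak of the compounds shown alone.

Measured in a functional assay on ACHN cells (Homo sapiens); a higher number here means a weaker inhibitor of growth, a lower number a stronger inhibitor of growth:
- compound 1 `O=S(=O)(/C=C/c1ccc(Cl)c(Cl)c1)Cc1ccc(Nc2ncnc3ccccc23)cc1`: 28000 nM
- compound 2 `O=S(=O)(/C=C/c1ccc(Br)cc1)Cc1ccc(Nc2ncnc3ccccc23)cc1`: 200 nM
- compound 3 `O=S(=O)(/C=C/c1ccc(C(F)(F)F)cc1F)Cc1ccc(Nc2ncnc3ccccc23)cc1`: 100000 nM

Compound 3 has the highest number of the three, with a 3.6-fold higher number from compound 1 to compound 3 (0.55 log units; beyond the scatter) and a 500-fold higher number from compound 2 to compound 3 (2.70 log units; beyond the scatter). Compound 4 `O=S(=O)(/C=C/c1ccc(C(F)(F)F)cc1F)Cc1ccc(Nc2ncnc3ccc(Br)cc23)cc1` keeps the phenyl group of compound 3 and alters the shared core: bromo in place of hydrogen on an aromatic carbon. Among the measured compounds shown here, no measured step touches this place. All three steps, including a 140-fold lower number from compound 1 to compound 2 (2.15 log units; beyond the scatter), exchange the phenyl group on the double-bonded chain carbon, so they show only that this assay can move widely within this series. They do not show what a bromo does on the core. A modest step to a lower number is expected, on weak grounds: compound 3 sits at the top of the three, and compound 1 at 28000 nM is the nearest value beneath it. The expected change is a 4.0-fold lower number from compound 3 to compound 4 (0.60 log units; beyond the scatter). For compound 4 the estimated value is 25000 nM, with an expected range of 3000 nM to 150000 nM.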

Compound 4, concentration for 50% growth inhibition: 16000 nM
Compound 4: the middle estimate sits 1.6-fold (0.19 log units) above what was measured; measured number inside the range.
By their numbers in this assay, from the lowest: compound 2; then compounds 4 and 1 (each within the scatter of the next); then compound 3.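

In this assay, among the compounds shown here, bromo in place of hydrogen on an aromatic carbon of the shared core gives a 6.3-fold lower number from compound 3 to compound 4 (0.80 log units; beyond the scatter) as the first reading at this place, where every earlier step exchanged the phenyl group. The core position therefore moves the number in its own right while the 2-fluoro-4-(trifluoromethyl)phenyl group stays fixed, and the single added bromine is tolerated in the direction of stronger growth inhibition. No measured evidence is available to account for this step.

On these data alone, whether bromo on the core would act alike with the 4-bromophenyl group of compound 2 or the 3,4-dichlorophenyl group of compound 1 remains open. Also open, as far as these compounds go, is how another group on the same aromatic carbon, such as chloro, methoxy or an amine, would compare with bromo.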